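The source may report more compounds than this note shows. Statements on the series, on what has been measured and on what is new or still open speak of the compounds shown alone.

Compounds measured in a functional assay on KOPN-8 cells (Homo sapiens) for antiproliferative activity, with a stated time of 72 h; on this read-out lower numbers stand for an effect already at smaller amounts and higher numbers for an effect only at larger amounts of compound:
compound 1 `COc1ccc(-c2cc(=O)c3c(OC)cc(OC)cc3[nH]2)cc1` gives > 31100 nM
compound 2 `COc1ccc(-c2cc(=O)c3c(OC)cc(OC)cc3n2C)cc1` gives 30000 nM

The value of compound 1 in this assay is only a limit, not a number (the limit of > 31100 nM in this assay, at which 1 of the 2 values shown sits). Compound 2 differs by methyl in place of hydrogen on an aromatic nitrogen, and the step of an at least 1.0-fold lower number from compound 1 to compound 2 (0.01 log units; that floor lies within the scatter) stays within the scatter. Compound 3 `COc1ccc(-c2[nH]c3cc(OC)cc(OC)c3c(=O)c2I)cc1` carries iodo in place of hydrogen on an aromatic carbon. For the measured compounds named here, none of the measured steps concerns a change at this aromatic carbon, so no direction can be drawn from them. Compound 3 is therefore expected to stay close to the starting point, with a step of an at least 1.2-fold lower number from compound 1 to compound 3 (0.09 log units; that floor lies within the scatter). Compound 3 is estimated at 25000 nM, within 5000 nM to 40000 nM.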

Compound 3, half-maximal effective concentration: 49400 nM
Beside the measured number, compound 3's estimate is 2.0-fold (0.30 log units) below it; the whole stated range lies below it.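

The step from compound 1 to compound 3 cannot be read, because the value of compound 1 is only a limit, not a number: the limit of > 31100 nM in this assay, at which 1 of the 3 values shown sits.

The compounds shown leave open whether iodo in place of hydrogen on this aromatic carbon changes the number at all.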